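Cyclohexyl amides of an isoxazole acid: step from phenyl to isopropyl

This account rests on a few compounds, and the source may have more. Where it says the series, first, only, none or still open, it means among the compounds named here.

Measured so far:
compound 1 `CC1CCCCC1N(C(=O)c1cc(C2CC2)on1)C1CCCCC1C`, an assay on isolated protein for agonist activity at sphingosine 1-phosphate receptor 4 (Homo sapiens); on this read-out higher numbers stand for an effect only at larger amounts of compound and lower numbers for an effect already at smaller amounts: > 50000 nM
compound 2 `O=C(c1cc(-c2ccccc2)on1)N(C1CCCCC1)C1CCCCC1`, this assay: > 50000 nM

In this assay compound 1 reaches only the limit of the assay, not a number, with > 50000 nM. In this assay compound 2 likewise sits at the limit and gives no number, > 50000 nM. Compound 2 therefore stands where every value shown stands: the limit of > 50000 nM in this assay, at which 2 of the 2 values shown sit. Among the measured compounds shown here, no step between measured compounds is available for comparison.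

Compound 3 `CC(C)c1cc(C(=O)N(C2CCCCC2)C2CCCCC2)no1` is not yet measured. It differs from compound 2 in one place: isopropyl in place of phenyl on an aromatic carbon. Both measured compounds show no effect up to the limit, so for the change from compound 2 to compound 3 no shift beyond the usual scatter is expected, and the most likely outcome is again a limit rather than a number.

The estimate for compound 3 in this assay is 50000 nM, with a range from 20000 nM to 200000 nM. This estimate implies a step from compound 2 to compound 3 of a number no higher from compound 2 to compound 3 (the limit leaves the size open), expected to be none beyond the scatter.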

Compound 3, half-maximal effective concentration: > 50000 nM
Compound 3 ended at the assay's limit; the forecaster's own chance of this, stated with the estimate: 80%; the middle value lies on the limit itself.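

No step can be read between compound 2 and compound 3 in this assay, as both values are limits and not numbers. The series so far stands at a single place: the limit of > 50000 nM in this assay, at which 3 of the 3 values shown sit.

The compounds shown leave open how far any of them lies from that limit and which change to the shared core would give a number in this assay.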